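A few compounds are considered here, and "the series" means these few. Any claim that something is new, unique, unknown or untested is made for them only; others in the source may bear on it.

Measured so far:
compound 1 `Cc1cc(=O)n(-c2ccc(Br)cc2F)nc1C(=O)Nc1ccc(Oc2ncnc3c2ccn3C)cc1` gives 18800 nM
compound 2 `Cc1cc(=O)n(-c2ccc(Br)cc2F)nc1C(=O)Nc1ccc(Oc2ncnc3c2ccn3C)c(F)c1` gives 6670 nM

In a functional assay on PC-3 cells (Homo sapiens) for cytotoxicity, read by MTT assay, with a stated time of 72 h (on this read-out lower numbers stand for stronger inhibition and higher numbers for weaker inhibition), compound 1 gives 18800 nM and compound 2 gives 6670 nM. Going by the values given here, compound 2 thus stands lowest of the two numbers available; the only measured step, a 2.8-fold lower number from compound 1 to compound 2 (0.45 log units; beyond the scatter), is what separates it from compound 1, and that step came from a fluoro replacing a hydrogen on the amide-bearing ring.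

Compound 3 `Cc1cc(=O)n(-c2ccccc2Cl)nc1C(=O)Nc1ccc(Oc2ncnc3c2ccn3C)c(F)c1` differs from compound 2 by 2-chlorophenyl in place of 4-bromo-2-fluorophenyl on an aromatic nitrogen. Among the compounds with values here, no measured step touches this part of the molecule: the one step known, a 2.8-fold lower number from compound 1 to compound 2 (0.45 log units; beyond the scatter), concerns a different place and offers no guide to swapping one halogenated phenyl for another. With nothing directly comparable, the expected step of a 1.2-fold higher number from compound 2 to compound 3 (0.08 log units; within the scatter) is kept small and its direction is uncertain. Compound 3 is therefore estimated at 8000 nM, with a range from 2000 nM to 32000 nM.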

Compound 3, half-maximal inhibitory concentration: > 60000 nM
Compound 3 was reported as a limit (the forecaster's own chance of this, stated with the estimate: 10%); at least 7.5-fold (0.87 log units) between middle value and limit.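

Going by these compounds alone, compound 3 keeps the fluoro on the amide-bearing ring of compound 2, so the only change is on the aromatic nitrogen, where 2-chlorophenyl replaces 4-bromo-2-fluorophenyl, and this gives an at least 8.9-fold higher number from compound 2 to compound 3 (0.95 log units; beyond the scatter) in this assay. The earlier compounds shown here varied only the amide-bearing ring; this pair shows that the aryl group on the nitrogen is not a neutral spot and that the cell read-out responds to it as well. The reading for compound 3 is a limit and not a number: the limit of > 60000 nM in this assay, at which 1 of the 3 values shown sits.

This single change removes bromine and fluorine and brings in chlorine, so the compounds shown cannot say which of these matters. From the compounds shown here alone, how a plain phenyl, or a phenyl carrying an amine or a carboxylic acid, would behave at this position remains open.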